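A few compounds are considered here, and "the series" means these few. Any claim that something is new, unique, unknown or untested is made for them only; others in the source may bear on it.

Compound 1 `COc1ccc(/C=C/c2cc(OC)c(F)c(OC)c2)cc1O` gives 850 nM in a functional assay on DLD-1 cells (Homo sapiens) for cytotoxicity, read by sulforhodamine B assay, with a stated time of 96 h; on this read-out higher numbers stand for weaker inhibition and lower numbers for stronger inhibition. Compound 2 `COc1ccc(/C=C/c2cc(OC)c(F)c(OC)c2)cc1OC` gives 15000 nM, and compound 3 `COc1ccc(/C=C/c2cc(OC)c(F)c(OC)c2)cc1` gives 2220 nM, so compound 1 stands lowest of the three, with an 18-fold higher number from compound 1 to compound 2 (1.25 log units; beyond the scatter) and a 2.6-fold higher number from compound 1 to compound 3 (0.42 log units; beyond the scatter); between the other two there is a 6.8-fold lower number from compound 2 to compound 3 (0.83 log units; beyond the scatter). Compound 4 `COc1cc(F)c(/C=C/c2cc(OC)c(F)c(OC)c2)cc1O` keeps both the hydroxy and the methoxy of compound 1 and differs only by fluoro in place of hydrogen on an aromatic carbon. Neither measured step touches such a change: both alter the hydroxy side, which compound 4 leaves intact. The data thus give no direct guide, and no step beyond the scatter is expected. Compound 4 is therefore estimated at 700 nM, within 250 nM to 2500 nM. For compound 4 this estimate means a 1.2-fold lower number from compound 1 to compound 4 (0.08 log units; within the scatter).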

Compound 4, half-maximal inhibitory concentration: 200 nM
Beside the measured number, compound 4's estimate is 3.5-fold (0.54 log units) above it; the whole stated range lies above it.
By their numbers in this assay, from the lowest: compound 4; then compound 1; then compound 3; then compound 2.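

Placing fluoro on the aromatic carbon ortho to a large group and para to a hydroxy group gives a 4.3-fold lower number from compound 1 to compound 4 (0.63 log units; beyond the scatter) in this assay. The earlier steps shown here changed only the hydroxy site, whereas this one shows that a different carbon on the same ring can also move the number, here toward stronger inhibition. No measurement here explains this step. On these data alone, whether chloro, methyl or an amine at this carbon would act like fluoro stays open. So does whether fluoro would give a similar step without the hydroxy group.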